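Fluorine placement on the benzylsulfanyl arm

The source may hold more compounds than are shown below. What is called first, only, known or untested is meant among the compounds shown, and "the series" means these compounds.

Compound 1 `Cc1ccc(-c2cc(-c3ccc(Br)cc3)nc(SCc3ccccc3Br)n2)cc1` and compound 2 `Fc1ccccc1CSc1nc(-c2ccc(Br)cc2)cc(-c2ccc(Br)cc2)n1` share one core. In an assay on isolated protein for inhibition of Alpha glucosidase (Homo sapiens), read by spectrophotometry, with stated times of 15 min and 30 min (on this read-out lower numbers stand for stronger inhibition and higher numbers for weaker inhibition), compound 1 gives 19000 nM. In this assay compound 2 gives 19000 nM, level with compound 1 at the digits shown and within the scatter. Compound 3 `Fc1ccc(CSc2nc(-c3ccc(Br)cc3)cc(-c3ccc(Br)cc3)n2)cc1` differs from compound 2 by 4-fluorophenyl in place of 2-fluorophenyl on a saturated chain carbon bound to a sulfur. Within the data shown here, no measured pair shows the effect of such a change. The step of no change at the digits printed from compound 2 to compound 3 (within the scatter) is expected to stay within the scatter, with no clear direction. Compound 3 is expected to give 19000 nM in this assay, between 8000 nM and 45000 nM.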

Compound 3, half-maximal inhibitory concentration: 19000 nM
Estimate against measurement, compound 3: no gap at the digits printed; low and high end bracket the measured number.
By their numbers in this assay, from the lowest: compounds 1, 2 and 3 (each within the scatter of the next).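

Within the (2-fluorobenzyl)sulfanyl arm, the change to (4-fluorobenzyl)sulfanyl gives the first readable single-place step in this series: in this assay it shows no change at the digits printed from compound 2 to compound 3 (within the scatter) and so places the two fluorine placements level. Nothing at hand accounts for this result.

Open, going by these compounds, is whether this arm responds to anything beyond a fluorophenyl exchange, such as an amine or a carboxylic acid on the phenyl ring, or a longer chain between the sulfur and that ring. On these data alone, the two bromophenyl groups on the shared core also remain untested by any single-place step.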